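Series notes: piperidin-1-yl in place of benzyloxy, compound 3

A few compounds are considered here, and "the series" means these few. Any claim that something is new, unique, unknown or untested is made for them only; others in the source may bear on it.

compound 1 `Cc1cc(Br)c(S(C)(=O)=O)cc1C(=O)N=C(N)N` — 12 nM in a functional assay for inhibition of sodium/hydrogen exchanger (Oryctolagus cuniculus); on this read-out higher numbers stand for weaker inhibition and lower numbers for stronger inhibition
compound 2 `Cc1cc(OCc2ccccc2)c(S(C)(=O)=O)cc1C(=O)N=C(N)N` — 28 nM

Among the compounds with values here, compound 2 holds the highest of the two numbers measured so far; the only measured step, a 2.3-fold higher number from compound 1 to compound 2 (0.37 log units; beyond the scatter), separates it from the other value. Compound 3 `Cc1cc(N2CCCCC2)c(S(C)(=O)=O)cc1C(=O)N=C(N)N` differs from compound 2 in one place: piperidin-1-yl in place of benzyloxy on an aromatic carbon. Within the data shown here, no measured step involves piperidin-1-yl. Among the measured compounds shown here, the one step at this aromatic carbon, a 2.3-fold higher number from compound 1 to compound 2 (0.37 log units; beyond the scatter), was modest, so only a modest step in this assay is expected here, in either direction or none beyond the scatter. Compound 3 is estimated at 25 nM (range 8 nM to 80 nM). This estimate for compound 3 means an expected step of a 1.1-fold lower number from compound 2 to compound 3 (0.05 log units; within the scatter).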

Compound 3, half-maximal inhibitory concentration: 21 nM
For compound 3 the middle estimate is 1.2-fold (0.08 log units) above the measured one; the measured number falls inside the stated range.
By their numbers in this assay, from the lowest: compounds 1, 3 and 2 (each within the scatter of the next, the first and the last beyond it).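

In this assay, the aromatic carbon ortho to a methylsulfonyl group accepts a non-aromatic ring as readily as benzyloxy (a 1.3-fold lower number from compound 2 to compound 3 (0.12 log units; within the scatter)). Piperidin-1-yl also stays within the scatter of bromo (a 1.8-fold higher number from compound 1 to compound 3 (0.24 log units; within the scatter)), whereas benzyloxy lies beyond it (a 2.3-fold higher number from compound 1 to compound 2 (0.37 log units; beyond the scatter)), though piperidin-1-yl and benzyloxy themselves cannot be told apart. No evidence is available on what lies behind these readings.

Open, as far as these compounds go, is whether a smaller amine such as dimethylamino, a morpholin-4-yl ring or a carboxylic acid on a longer chain would keep the number in this range.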